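The compounds below may be only part of what the source reports. "The series", "measured", "known", "first", "only" and "open" are said of these compounds alone.

Compound 1 `CO[C@@H]1[C@H](OC(=O)NC(=O)CCl)CO[C@]2(COC(C)(C)O2)[C@@]1(OC(=O)NC(=O)CCl)C1OC1CCCc1ccccc1` is the reference point here. In a functional assay on A-431 cells (Homo sapiens) for antiproliferative activity (on this read-out higher numbers stand for weaker inhibition and lower numbers for stronger inhibition), compound 1 gives 3700 nM, and that is the only single number shown for it; a further entry carries no single number. Compound 2 `CO[C@@H]1[C@H](OC(=O)NC(=O)CCl)CO[C@]2(COC(C)(C)O2)[C@@]1(O)C1OC1CCCc1ccccc1` has been measured more than once: in this assay compound 2 gives 19000 nM; 29000 nM (2 entries), and the spread of those repeats the several entries of compound 2 in this assay, 19000 nM; 29000 nM (2 entries) shows how far the same compound can move between runs. No step between these two measured compounds has been worked out, so their values are simply set side by side, with compound 1 sitting at the stronger-inhibiting end of what is shown.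

The unmeasured compound 3 `CO[C@@H]1[C@H](OC(=O)NC(=O)CCl)CO[C@]2(COC(C)(C)O2)[C@]1(CCCCCc1ccccc1)OC(=O)NC(=O)CCl` differs from compound 1 in one place: 5-phenylpentyl in place of 3-(3-phenylpropyl)oxiran-2-yl on a saturated ring carbon. With the three-membered ring gone and only a hydrocarbon chain left in its place, the change is expected to weaken inhibition well beyond the scatter, the step of an 8.1-fold higher number from compound 1 to compound 3 (0.91 log units; beyond the scatter) being the expected shift in this assay. Compound 3 is therefore estimated at 30000 nM, with a plausible range from 6000 nM to 150000 nM.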

Compound 3, half-maximal inhibitory concentration: 1200 nM
Compound 3: middle estimate off by 25-fold (1.40 log units), on the high side; measured number below the stated range.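

In this assay, the oxirane ring proves dispensable at this saturated ring carbon: replacing 3-(3-phenylpropyl)oxiran-2-yl with 5-phenylpentyl gives a 3.1-fold lower number from compound 1 to compound 3 (0.49 log units; beyond the scatter), a modest gain in inhibition rather than a loss. A plain hydrocarbon chain ending in a phenyl ring, with no hydrogen-bond acceptor in the group, is therefore tolerated at this position, so in this pair the activity does not depend on keeping the three-membered ring. The step lies beyond the usual scatter, though it remains modest, and repeat measurements give a concrete sense of how far a number can move between runs: the several entries of compound 2 in this assay, 19000 nM; 29000 nM (2 entries)

As far as these compounds go, the role of chain length remains open, as does the effect of a polar end group: a shorter chain, a longer chain, or an amine or carboxylic acid at the chain end could shift the number in either direction. Both groups in this pair also end in a phenyl ring, so they cannot show whether that ring matters, and a chain without it, such as a simple pentyl group, would be needed to answer that question.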